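Ring size at the amide carbonyl of a bicyclic core

The source may report more compounds than this note shows. Statements on the series, on what has been measured and on what is new or still open speak of the compounds shown alone.

Three compounds have been measured in an assay on CHO cells for agonist activity at Neuronal acetylcholine receptor; alpha3/alpha6/beta2/beta3 (Homo sapiens), read by FLIPR and calcium flux; on this read-out higher numbers stand for an effect only at larger amounts of compound and lower numbers for an effect already at smaller amounts:
compound 1 `CC(=O)N1CC2CC(C1)N2`: 750 nM
compound 2 `O=C(C1CCC1)N1CC2CC(C1)N2`: 370 nM
compound 3 `O=C(C1CCCC1)N1CC2CC(C1)N2`: 1600 nM

Compound 2 stands lowest of the three. Compound 1 lies above it by the step of a 2.0-fold lower number from compound 1 to compound 2 (0.31 log units; beyond the scatter), and compound 3, carrying cyclopentyl, shows a still higher number. Compound 4 `O=C([C@@H]1C[C@H]1F)N1CC2CC(C1)N2` is not yet measured; it differs from compound 2 in one place: 2-fluorocyclopropyl in place of cyclobutyl on a carbonyl carbon. Among the compounds with values here, only one measured step touches this carbonyl carbon, a 2.0-fold lower number from compound 1 to compound 2 (0.31 log units; beyond the scatter), and no measured compound carries fluorine, so the fluorine's effect is unknown. The step is expected to be small and toward a higher number, a 1.6-fold higher number from compound 2 to compound 4 (0.21 log units; within the scatter). Compound 4 is therefore estimated at 600 nM, within 200 nM to 1800 nM.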

Compound 4, half-maximal effective concentration: 53 nM
For compound 4 the middle estimate is 11-fold (1.05 log units) above the measured one; measured number below the stated range.
By their numbers in this assay, from the lowest: compound 4; then compound 2; then compound 1; then compound 3.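

In this assay, within the data shown here, the group on the carbonyl carbon can shift the number much further than the earlier compounds showed: 2-fluorocyclopropyl in place of cyclobutyl gives a 7.0-fold lower number from compound 2 to compound 4 (0.84 log units; beyond the scatter) even though both groups count 4 heavy atoms. Set against methyl, the same group gives a 14-fold lower number from compound 1 to compound 4 (1.15 log units; beyond the scatter) and this is the largest step seen at this position. Nothing measured here explains the gain.

From the compounds shown here alone, whether it belongs to the three-membered ring or to the fluorine stays open, and plain cyclopropyl on the same carbonyl carbon would tell the two apart. The role of the 2 defined stereocentres is also unresolved.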